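This account rests on a few compounds, and the source may have more. Where it says the series, first, only, none or still open, it means among the compounds named here.

In an ADME assay on a cell-free system (plasma, Homo sapiens) for metabolic stability, read by LC-MS, using NADPH, with a stated time of 60 min, tested at 1 uM (a lower number here means that less of the compound is left, a higher number that more of the compound is left), compound 1 `CNC(=O)c1cc(S(=O)(=O)N2CCS[C@H]2C(=O)O[C@@H](Cc2c(Cl)c[n+]([O-])cc2Cl)c2ccc(OC(F)F)c(OCC3CC3)c2)cn1C` gives 100%, the higher of the two numbers available. Compound 2 `COc1ccc(S(=O)(=O)N2CCCC[C@H]2C(=O)O[C@@H](Cc2c(Cl)c[n+]([O-])cc2Cl)c2ccc(OC(F)F)c(OCC3CC3)c2)cc1C(=O)N(C)C` gives 88.2%, a gap beyond the usual scatter, but these two compounds differ in more than one place, so the gap cannot be tied to a single change. Compound 3 `COc1ccc(S(=O)(=O)N2CCS[C@H]2C(=O)O[C@@H](Cc2c(Cl)c[n+]([O-])cc2Cl)c2ccc(OC(F)F)c(OCC3CC3)c2)cc1OC` departs from compound 1 on a sulfonyl sulfur: a group of 10 heavy atoms (8 carbon, 2 oxygen; one six-membered aromatic ring of carbon only) in place of a group of 10 heavy atoms (7 carbon, 2 nitrogen, 1 oxygen; one five-membered aromatic ring with 1 hetero atom), on a sulfonyl sulfur. Within the data shown here, no measured step isolates this change. Compound 2 also carries a six-membered aromatic ring of carbon only on its sulfonyl sulfur and gives 88.2%, so only a modest fall is expected in this assay, possibly none beyond the scatter. The expected step is a number 10 percentage points lower from compound 1 to compound 3 (within the scatter). Compound 3 is estimated at 90%, with an expected range from 72% to 100%.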

Compound 3, percent of the compound remaining: 101%
Beside the measured number, compound 3's estimate is 11 percentage points below it; measured number outside the range, above it.
By their numbers in this assay, from the lowest: compound 2; then compounds 1 and 3 (each within the scatter of the next).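

In this assay, 3,4-dimethoxyphenyl on the sulfonyl sulfur, in place of the group with the five-membered aromatic ring, gives a number 1 percentage points higher from compound 1 to compound 3 (within the scatter). Among these compounds, this is the first single-place comparison at this position, and it shows that the two groups cannot be told apart in this read-out, even though the group that leaves carries a hydrogen-bond donor and 3,4-dimethoxyphenyl carries none. Nothing available bears on why the two compounds match.

The compounds shown leave open whether a group without an aromatic ring, such as cyclohexyl or a plain methyl, would match them on the sulfonyl sulfur. They also leave open whether a carboxylic acid or an amine on the six-membered aromatic ring would keep the read-out where it stands.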